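Amide substituent change on a dihydrofuran carboxamide core

A few compounds are considered here, and "the series" means these few. Any claim that something is new, unique, unknown or untested is made for them only; others in the source may bear on it.

Compound 1 `C=CC1=C(C(=O)NCc2ccc(Cl)cc2)C(c2ccc(OC)c(OC)c2)OC1` was tested in a functional assay on SW480 cells (Homo sapiens) for cytotoxicity, read by MTT assay, with a stated time of 24 h; on this read-out higher numbers stand for weaker inhibition and lower numbers for stronger inhibition. In this assay compound 1 gives only a limit, > 100000 nM, and no number. Compound 2 `C=CC1=C(C(=O)NCc2ccc(Cl)cc2)C(c2ccc(OC)cc2)OC1` likewise gives only a limit in this assay, > 100000 nM. Going by the values given here, the single measured step, a step that the two limits leave unreadable from compound 1 to compound 2, is therefore not readable, since both compounds sit at the same limit (the limit of > 100000 nM in this assay, at which 2 of the 2 values shown sit). Compound 3 `C=CC1=C(C(=O)NC2CCCCC2)C(c2ccc(OC)c(OC)c2)OC1` differs from compound 1 in one place: cyclohexyl in place of 4-chlorobenzyl on an amide-type nitrogen. Among the compounds with values here, no measured step bears directly on this change, and the only comparison available, that from compound 1 to compound 2, shows no size. With compound 1 at the limit of this assay, compound 3 is also expected to remain at or beyond that limit, and the step from compound 1 to compound 3 is estimated as a step that the limit leaves unreadable from compound 1 to compound 3. Compound 3 is accordingly estimated at 150000 nM, with a range from 30000 nM to 600000 nM.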

Compound 3, half-maximal inhibitory concentration: 19100 nM
Beside the measured number, compound 3's estimate is 7.9-fold (0.90 log units) above it; measured number outside the range, below it.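

Swapping 4-chlorobenzyl for cyclohexyl on the amide-type nitrogen moves the series off its ceiling in this assay, with an at least 5.2-fold lower number from compound 1 to compound 3 (0.71 log units; beyond the scatter), so this position can change the read-out, which the earlier pair could not show. The earlier step, hydrogen in place of methoxy on an aromatic carbon, cannot be read, so only the amide substituent has a visible effect so far. The size of the new step is a minimum and not an exact figure, since compound 1 gives only a limit: the limit of > 100000 nM in this assay, at which 2 of the 3 values shown sit.

The compounds shown leave open whether the shift follows from losing the chlorine, from losing the aromatic ring, or from the cyclohexyl itself. An unsubstituted benzyl or a cyclopentyl on the same nitrogen would begin to separate these possibilities.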